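A few compounds are considered here, and "the series" means these few. Any claim that something is new, unique, unknown or untested is made for them only; others in the source may bear on it.

Measured so far:
- compound 1 `N#Cc1ccc(-c2cncc(-c3cc4ccc(O)cc4[nH]3)c2)cc1`: 25000 nM
- compound 2 `CS(=O)(=O)c1ccc(-c2cncc(-c3cc4ccc(O)cc4[nH]3)n2)cc1`: 20000 nM
- compound 3 `Oc1ccc(-c2cncc(-c3cc4cc(O)ccc4[nH]3)n2)cc1`: 7000 nM

In a functional assay on NCI60 cells (Homo sapiens) for cytotoxicity, with a stated time of 48 h (on this read-out lower numbers stand for stronger inhibition and higher numbers for weaker inhibition), compound 3 has the lowest number of the three (7000 nM). Its gaps to compound 1 and to compound 2 both lie beyond the usual scatter, so it is the strongest inhibitor of this small set, although all three numbers are high.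

The next compound, compound 4 `CS(=O)(=O)c1ccc(-c2cncc(-c3cc4cc(O)ccc4[nH]3)n2)cc1`, has not been measured yet. It differs from compound 3 in one place: methylsulfonyl in place of hydroxy on an aromatic carbon, para to a large group (methylsulfonyl in place of hydroxy on an aromatic carbon).

For the measured compounds named here, no measured pair shows this change on its own, so any forecast rests on thin evidence. The closest guide is compound 2, which also carries methylsulfonyl and gives 20000 nM in this assay, a higher number than that of compound 3. Compound 2 and compound 4 are not the same, however, so its value is only a rough pointer.

A moderate move toward weaker inhibition is therefore expected, with the estimated step being a 2.1-fold higher number from compound 3 to compound 4 (0.33 log units; beyond the scatter) in the direction of a higher number. For compound 4 the estimated value is 15000 nM (expected range 6000 nM to 40000 nM).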

Compound 4, half-maximal inhibitory concentration: 15000 nM
Beside the measured number, compound 4's estimate shows no gap at the digits printed, and the stated range covers the measured number.
By their numbers in this assay, from the lowest: compound 3; then compounds 4, 2 and 1 (each within the scatter of the next).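

For the compounds shown here, compound 3 and compound 4 form the first pair in this set that differs in only one place, so the effect of a single change can finally be read in this assay. On the aromatic carbon para to a large group, methylsulfonyl entering in place of hydroxy gives a 2.1-fold higher number from compound 3 to compound 4 (0.33 log units; beyond the scatter), a modest weakening that lies beyond the usual scatter, even though the swap replaces a group of 1 heavy atom and 1 hydrogen-bond donor with one of 4 heavy atoms and 0 hydrogen-bond donors. No accompanying measurement explains why this step has the size it has.

With only these two groups compared on this core, a single pair cannot separate the loss of the hydrogen-bond donor from the gain in size or the added hydrogen-bond acceptors. A methoxy group, an amine or a carboxylic acid at the same position would help show which of these differences tracks the read-out, and whether any group there can bring the number below that of compound 3.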